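Removing a Second Methoxy from a Chalcone-Like Scaffold

The compounds below may be only part of what the source reports. "The series", "measured", "known", "first", "only" and "open" are said of these compounds alone.

Of the compounds shown here, two sharing one core have been tested in a functional assay on A549 cells (Homo sapiens) for antiproliferative activity, read by MTT assay, with a stated time of 24 h; a lower number here means a stronger inhibitor, a higher number a weaker inhibitor. Compound 1 `COc1ccc(-c2cc(/C=C/C(=O)c3ccc(OC)c(OC)c3)nc3cc(-c4ccccc4)nn23)cc1` gives 7400 nM. Compound 2 `COc1ccc(C(=O)/C=C/c2cc(-c3ccc(OC)cc3)n3nc(-c4ccccc4)cc3n2)cc1`, which keeps one methoxy less, gives 2900 nM. Among the measured compounds shown here, compound 2 therefore stands with the lower of the two numbers, its only neighbour being compound 1, and the step between them is a 2.6-fold lower number from compound 1 to compound 2 (0.41 log units; beyond the scatter).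

Compound 3 `COc1ccc(-c2cc(/C=C/C(=O)c3ccccc3)nc3cc(-c4ccccc4)nn23)cc1` takes the same kind of change one stage further: hydrogen in place of methoxy on an aromatic carbon, so that the (4-methoxyphenyl)carbonyl becomes a benzoyl. For the measured compounds named here, only the step from compound 1 to compound 2 bears on this, and it was a modest drop. A comparable modest drop, or none beyond the scatter, is expected in this assay; the estimated step is a 1.6-fold lower number from compound 2 to compound 3 (0.21 log units; within the scatter). Compound 3 is thus expected to give about 1800 nM, within a range from 700 nM to 5000 nM.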

Compound 3, half-maximal inhibitory concentration: 8600 nM
Beside the measured number, compound 3's estimate is 4.8-fold (0.68 log units) below it, outside the stated range (above it).
By their numbers in this assay, from the lowest: compound 2; then compounds 1 and 3 (each within the scatter of the next).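

In this assay, hydrogen in place of methoxy does not push the number in one direction: the earlier swap on this ring lowered it, whereas removing the remaining methoxy, para to a large group, gives a 3.0-fold higher number from compound 2 to compound 3 (0.47 log units; beyond the scatter) and so reverses that gain. Comparing the two ends of the series, phenyl in place of 3,4-dimethoxyphenyl gives a 1.2-fold higher number from compound 1 to compound 3 (0.07 log units; within the scatter) and leaves no change beyond the scatter, so compound 2, with its single methoxy, is the one that stands apart. Nothing available explains why the two swaps of the same kind pull in opposite directions.

Still open, from the compounds shown here alone, is whether a hydroxyl or an amine at this place on the ring would match the methoxy of compound 2. A larger ethoxy group there is equally untested among the compounds shown.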